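The compounds below may be only part of what the source reports. "The series", "measured", "known", "first", "only" and "open" are said of these compounds alone.

In a functional assay on A-375 cells (Homo sapiens) for inhibition, read by CCK-8 assay, with a stated time of 72 h, tested at 2 uM (a lower number here means less inhibition of growth, a higher number more inhibition of growth at the concentration tested), compound 1 (`Nc1ccccc1NC(=O)/C=C/c1ccc(CSc2cccc(F)c2)cc1`) gives 6.75%, compound 2 (`COc1ccc(SCc2ccc(C(=O)Nc3ccccc3N)cc2)cc1`) gives 10.2% and compound 3 (`Cc1ccc(SCc2ccc(C(=O)Nc3ccccc3N)cc2)cc1`) gives 17.5%. Compound 3 thus lies within the scatter of compound 2 and beyond the scatter of compound 1. Compound 4 (`Nc1ccccc1NC(=O)c1ccc(CSc2ccc(F)cc2)cc1`) carries fluoro in place of methyl on an aromatic carbon, para to a large group: fluoro in place of methyl on an aromatic carbon. Within the data shown here, the one measured step at this place is a number 7.3 percentage points higher from compound 2 to compound 3 (within the scatter), methyl in place of methoxy, and it stays within the scatter. Among the measured compounds shown here, no measured pair shows fluoro entering here, so the evidence is thin. In this assay, a number 4.5 percentage points lower from compound 3 to compound 4 (within the scatter) is the estimated step, which is a small drop and none beyond the scatter. For compound 4 the expected value is 13%, within an estimated range of 3% to 27%.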

Compound 4, percent growth inhibition at one concentration: 19.4%
Beside the measured number, compound 4's estimate is 6.4 percentage points below it; the range from low to high includes it.
By their numbers in this assay, from the lowest: compounds 1, 2, 3 and 4 (each within the scatter of the next, the first and the last beyond it).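

Fluoro on this aromatic carbon, para to a large group, gives a number 1.9 percentage points higher from compound 3 to compound 4 (within the scatter) in this assay when it replaces methyl, and a number 9.2 percentage points higher from compound 2 to compound 4 (within the scatter) when it replaces methoxy. With these steps, methoxy, methyl and fluoro at this position all lie within the scatter of one another, so fluoro joins the two earlier groups with no separation among the three. No available evidence bears on this result. The compounds shown leave open whether an amine or a carboxylic acid on this carbon would give a step beyond the scatter.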